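Three limits and an expected fourth in A549 cytotoxicity

The compounds below may be only part of what the source reports. "The series", "measured", "known", "first", "only" and "open" are said of these compounds alone.

Compound 1 `O=C(/C=C\c1ccc(F)cc1)N1N=C(c2ccncc2)OC1c1c[nH]c2ccccc12`: > 30 ug/mL
Compound 2 `O=C(/C=C\c1cccc(Cl)c1)N1N=C(c2ccncc2)OC1c1c[nH]c2ccccc12`: > 30 ug/mL
Compound 3 `O=C(/C=C\c1ccc(Cl)cc1)N1N=C(c2ccncc2)OC1c1c[nH]c2ccccc12`: > 30 ug/mL

Compound 1, compound 2 and compound 3 share one core and differ only in the aromatic ring carried on the ethenyl chain attached to the carbonyl carbon. In an ADME assay on A549 cells (Homo sapiens) for cytotoxicity, read by MTT assay, with a stated time of 48 h (a lower number here means a stronger inhibitor of growth, a higher number a weaker inhibitor of growth), compound 1 gives only a limit of the assay, > 30 ug/mL. Compound 2 likewise gives only a limit in this assay, > 30 ug/mL. Compound 3 also gives only a limit in this assay, > 30 ug/mL. All three results sit at the limit of > 30 ug/mL in this assay, at which 3 of the 3 values shown sit, so the three steps among them cannot be read: a step that the two limits leave unreadable from compound 1 to compound 2, a step that the two limits leave unreadable from compound 1 to compound 3 and a step that the two limits leave unreadable from compound 2 to compound 3. Compound 3 therefore stands with the other two at the limit, and no number sets it above or below them.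

Compound 4 `O=C(/C=C/c1c(Cl)cccc1Cl)N1N=C(c2ccncc2)OC1c1c[nH]c2ccccc12` differs from compound 3 by 2-(2,6-dichlorophenyl)ethenyl in place of 2-(4-chlorophenyl)ethenyl on a carbonyl carbon. Among the compounds with values here, the only steps that bear on this change are the three unreadable ones above, and none of them gives a size or a direction. The expectation for compound 4 is thus a step of no readable size, a step that the limit leaves unreadable from compound 3 to compound 4, and most likely another limit. Compound 4 is estimated at 40 ug/mL in this assay, with a range from 15 ug/mL to 120 ug/mL.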

Compound 4, concentration for 50% growth inhibition: > 30 ug/mL
Compound 4 ended at the assay's limit; the forecaster's own chance of this, stated with the estimate: 80%; the middle value does not contradict the limit.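

Compound 4 gives only a limit in this assay, > 30 ug/mL. Its steps to compound 1, compound 2 and compound 3 therefore cannot be read, and all four stand together: the limit of > 30 ug/mL in this assay, at which 4 of the 4 values shown sit.

The compounds shown leave open how large any effect of changing the aromatic ring on the ethenyl chain is, and in which direction it runs.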